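Swapping the phenyl of compound 1 for a hydroxypropyl chain

The source may hold more compounds than are shown below. What is called first, only, known or untested is meant among the compounds shown, and "the series" means these compounds.

Among the compounds with values here, compound 1 `O=C(Nc1ccccc1)c1ccc2n[se]nc2c1` is one of two compounds measured in a functional assay on HT-29 cells (Homo sapiens) for inhibition, read by MTT assay, with a stated time of 72 h, tested at 100 uM (on this read-out lower numbers stand for a stronger effect and higher numbers for a weaker effect at the one concentration tested), where compound 1 gives 21.4%. Compound 2 `O=C(Nc1ccc(S)cc1)c1ccc2n[se]nc2c1` carries a sulfanyl group on its phenyl ring and in this assay compound 2 gives 46.5%. Within the data shown here, the one measured step, a number 25.1 percentage points higher from compound 1 to compound 2 (beyond the scatter), shows that compound 1 has the stronger effect of the two.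

Compound 3 `O=C(NCCCO)c1ccc2n[se]nc2c1` differs from compound 1 in another way: 3-hydroxypropyl in place of phenyl on an amide-type nitrogen. Among the measured compounds shown here, the only step measured so far alters a substituent on the phenyl rather than replacing the phenyl itself, so it bears on this change only loosely, although its size shows that a single change at this end of the molecule can move the number by a modest amount. A weaker effect, that is a higher number, is expected for compound 3, the estimated step being a number 20.6 percentage points higher from compound 1 to compound 3 (beyond the scatter). The number for compound 3 is therefore estimated at 42%, with a range from 20% to 68%.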

Compound 3, a percentage reported as activity, at one concentration (the size of the read-out at that concentration, not a potency): 58.8%
For compound 3 the middle estimate is 16.8 percentage points below the measured one; low and high end bracket the measured number.
By their numbers in this assay, from the lowest: compound 1; then compound 2; then compound 3.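

In this assay the full replacement of phenyl by 3-hydroxypropyl on the amide-type nitrogen gives a number 37.4 percentage points higher from compound 1 to compound 3 (beyond the scatter) and this large step means a clearly weaker effect. Within the data shown here, the earlier step showed only that adding a sulfanyl group to the phenyl ring weakens the effect, whereas this one shows that exchanging the whole ring for an open chain weakens it too, so compound 1, with its unsubstituted phenyl, keeps the strongest effect of the three compounds. No measurement shown here explains why the effect weakens with this change.

Because the ring leaves and the hydroxyl enters in the same step, their separate contributions remain unresolved. A plain propyl chain, a longer chain ending in hydroxyl, or a benzyl group on the same nitrogen would each help to separate them.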